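The source may report more compounds than this note shows. Statements on the series, on what has been measured and on what is new or still open speak of the compounds shown alone.

Measured compounds in an in vitro assay on Sf9 cells for inhibition of 17-beta-hydroxysteroid dehydrogenase type 1 (Homo sapiens), tested at 1 uM; on this read-out lower numbers stand for a weaker effect and higher numbers for a stronger effect at the one concentration tested:
Compound 1 `O=C(c1c(O)ccc2cc(-c3cccc(O)c3)ccc12)N1CCCCC1`, giving 73%.
Compound 2 `O=C(Nc1ccccc1)c1c(O)ccc2cc(-c3cccc(O)c3)ccc12`, giving 80%.
Compound 3 `O=C(Nc1ccccc1)c1cc2cc(-c3cccc(O)c3)ccc2cc1O`, giving 62%.

Compound 1 stands second highest of the three. Its nearest neighbour is compound 2, with a number 7 percentage points higher from compound 1 to compound 2 (within the scatter); compound 3 lies lower, beyond the scatter.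

Compound 4 `CNC(=O)/C=C/c1c(O)ccc2cc(-c3cccc(O)c3)ccc12` differs from compound 1 by 2-(methylcarbamoyl)ethenyl in place of (piperidin-1-yl)carbonyl on an aromatic carbon. Within the data shown here, the only measured step at this carbon is the one from compound 1 to compound 2, which swapped the partner of the carbonyl and stayed within the scatter. Among the measured compounds shown here, no measured step removes the carbonyl from the ring or inserts an ethenyl link, so the change in compound 4 is not covered; the series tolerates variation here, but a loss beyond the scatter cannot be excluded. For compound 4 a modest drop is expected, a number 9 percentage points lower from compound 1 to compound 4 (within the scatter), with an estimated 64% ranging from 45% to 82%.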

Compound 4, a percentage reported as inhibition, at one concentration (the size of the read-out at that concentration, not a potency): 58%
For compound 4 the middle estimate is 6 percentage points above the measured one; the measured number falls inside the stated range.
By their numbers in this assay, from the lowest: compounds 4 and 3 (each within the scatter of the next); then compounds 1 and 2 (each within the scatter of the next).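

In this assay the entry of 2-(methylcarbamoyl)ethenyl on this aromatic carbon, ortho to a hydroxy group, brings a number 15 percentage points lower from compound 1 to compound 4 (beyond the scatter) when it replaces (piperidin-1-yl)carbonyl and a number 22 percentage points lower from compound 2 to compound 4 (beyond the scatter) when it replaces phenylcarbamoyl. The position therefore does not tolerate every change, whereas exchanging only the partner of the carbonyl stayed within the scatter. Nothing available explains this loss.

The compounds shown leave open whether the loss follows the ethenyl link or the methylcarbamoyl end. A carboxylic acid on the same ethenyl link, or a saturated ethyl link carrying methylcarbamoyl, would separate the two.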